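The compounds below may be only part of what the source reports. "The series", "measured", "known", "first", "only" and "open" are said of these compounds alone.

Two members of the series have been run so far in an ADME assay on HUVEC cells (Homo sapiens) for antiproliferative activity, read by MTT assay, with a stated time of 48 h; a higher number here means a weaker inhibitor, a lower number a stronger inhibitor. Compound 1 `N#CC1=C(N)Oc2c(c3nc4ccccc4nc3c3ccccc23)C12C(=O)N(Cc1cnnn1-c1ccc(N)cc1)c1ccccc12` returns only a limit of the assay there, > 50000 nM in this assay. Compound 2 `N#CC1=C(N)Oc2c(N)cc3nc4ccccc4nc3c2C12C(=O)N(Cc1cnnn1-c1cccc(Br)c1)c1ccccc12` likewise gives no number but a limit in this assay, > 50000 nM. Going by the values given here, both measured values therefore stand at the same place, (the limit of > 50000 nM in this assay, at which 2 of the 2 values shown sit), so no step between measured compounds can be drawn and compound 2 cannot be set above or below compound 1 on these numbers. Compound 3 `N#CC1=C(N)Oc2c(N)cc3nc4ccccc4nc3c2C12C(=O)N(Cc1cnnn1-c1ccc(Cl)cc1[N+](=O)[O-])c1ccccc12` is still to be run in this assay. It differs from compound 2 in one place: 4-chloro-2-nitrophenyl in place of 3-bromophenyl on an aromatic nitrogen. With both measured compounds sitting at the limit there is no basis to expect a step in either direction beyond the scatter, and the step expected is a step that the limit leaves unreadable from compound 2 to compound 3. For compound 3 the estimate in this assay is 60000 nM, within 20000 nM to 200000 nM, with a limit again the most likely outcome.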

Compound 3, half-maximal inhibitory concentration: > 50000 nM
Compound 3 was reported as a limit; the forecaster's own chance of this, stated with the estimate: 80%; the middle value does not contradict the limit.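

In this assay, going by these compounds alone, compound 3 gives > 50000 nM, a limit and not a number, so no step from compound 2 to compound 3 can be read: the limit of > 50000 nM in this assay, at which 3 of the 3 values shown sit. The compounds shown leave open whether any member of the series reaches a readable value in this assay.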